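Pyrimidinyl sulfanyl in place of thiadiazolyl sulfanyl: compound 3

The source may hold more compounds than are shown below. What is called first, only, known or untested is meant among the compounds shown, and "the series" means these compounds.

Measured so far:
compound 1 `Cc1nnc(SCC(=O)N/N=c2/scc(-c3ccccc3)n2-c2ccccc2)s1`: 63.9%
compound 2 `Cc1nnc(SCC(=O)N/N=c2/scc(-c3ccc(Cl)cc3)n2-c2ccccc2)s1`: 37.9%

Going by the values given here, in a functional assay on C6 cells (Rattus norvegicus) for cytotoxicity, read by MTT assay, with a stated time of 24 h, tested at 50 ug/mL (on this read-out lower numbers stand for a stronger effect and higher numbers for a weaker effect at the one concentration tested), compound 2 gives the lower of the two numbers at hand; the only measured step, a number 26 percentage points lower from compound 1 to compound 2 (beyond the scatter), separates it from compound 1. Compound 3 `O=C(CSc1ncccn1)N/N=c1/scc(-c2ccc(Cl)cc2)n1-c1ccccc1` is derived from compound 2 by pyrimidin-2-yl in place of 5-methyl-1,3,4-thiadiazol-2-yl on a sulfur. Among the compounds with values here, no measured step touches the group on the sulfur; the one step available concerns chloro in place of hydrogen on an aromatic carbon and says nothing about this change. For compound 3 the expected step is therefore a number 2.1 percentage points higher from compound 2 to compound 3 (within the scatter), nothing beyond the scatter. Compound 3 is estimated at 40%, with a range from 22% to 60%.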

Compound 3, a percentage reported as activity, at one concentration (the size of the read-out at that concentration, not a potency): 61.8%
Compound 3: middle estimate off by 21.8 percentage points, on the low side, and the stated range ends below it.
By their numbers in this assay, from the lowest: compound 2; then compounds 3 and 1 (each within the scatter of the next).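

In this assay, going by these compounds alone, the group on the sulfur counts: pyrimidin-2-yl in place of 5-methyl-1,3,4-thiadiazol-2-yl gives a number 23.9 percentage points higher from compound 2 to compound 3 (beyond the scatter) and so moves the read-out beyond the scatter, where the earlier compounds showed only a change at the chloro. The chloro alone therefore does not secure a low number, since compound 3 carries it as well. Nothing at hand explains this step. Still open, on these data alone, is whether this step holds without the chloro. A pyridin-2-yl group or an aminoethyl chain on the sulfur would show how narrowly the 5-methyl-1,3,4-thiadiazol-2-yl group is required.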